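A Larger Sulfonyl Group on the Most Stable Compound

The compounds below may be only part of what the source reports. "The series", "measured", "known", "first", "only" and "open" are said of these compounds alone.

Within the data shown here, in an ADME assay on microsomes from liver (Rattus norvegicus) for metabolic stability, with a stated time of 10 min, tested at 0.5 uM (a lower number here means that less of the compound is left, a higher number that more of the compound is left), compound 2 (`CC(C)COc1ccc(-c2cn(C)c3cc(C(=O)NS(C)(=O)=O)c(F)cc23)cn1`) gives 98% and holds the highest of the three numbers measured so far. Compound 3 (`CC(C)COc1ncc(-c2cn(C)c3cc(C(=O)NS(C)(=O)=O)c(F)cc23)cc1Cl`) comes next with 85% remaining, and compound 1 (`CC(C)COc1ncc(-c2cn(C)c3cc(C(=O)NS(=O)(=O)C4CC4)c(F)cc23)cc1Cl`) is lowest with 37% remaining. Compound 4 (`CC(C)COc1ccc(-c2cn(C)c3cc(C(=O)NS(=O)(=O)C4CC4)c(F)cc23)cn1`) alters a single group of compound 2, with cyclopropyl in place of methyl on a sulfonyl sulfur.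

The closest evidence is the same swap run in reverse, which gave a number 48 percentage points higher from compound 1 to compound 3 (beyond the scatter) when methyl replaced cyclopropyl. Both compounds in that pair carry a chloro group that compound 2 lacks. The chloro change itself, seen as a number 13 percentage points lower from compound 2 to compound 3 (beyond the scatter) for chloro in place of hydrogen on an aromatic carbon, is only modest, so the swap may well carry over to a compound without chloro. Still, this is a single pair, and its size may not transfer exactly. Read backwards, it points to a large fall, and the expected change is a number 46 percentage points lower from compound 2 to compound 4 (beyond the scatter) by this estimate. Compound 4 is estimated at 52% remaining, with an expected range from 35% to 72% across repeat measurements.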

Compound 4, percent of the compound remaining: 78%
Beside the measured number, compound 4's estimate is 26 percentage points below it, outside the stated range (above it).
By their numbers in this assay, from the lowest: compound 1; then compounds 4 and 3 (each within the scatter of the next); then compound 2.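

Cyclopropyl in place of methyl on a sulfonyl sulfur still lowers the number in this assay, giving a number 20 percentage points lower from compound 2 to compound 4 (beyond the scatter), so the direction seen in the chloro compounds holds without chloro, but the size of the change depends on the rest of the compound: the same change on two cores in this assay, a number 48 percentage points higher (beyond the scatter) from compound 1 to compound 3 and a number 20 percentage points higher (beyond the scatter) from compound 4 to compound 2, 28 percentage points apart, beyond the scatter of two such steps. The chloro position shows the same dependence, with a number 41 percentage points higher from compound 1 to compound 4 (beyond the scatter) for hydrogen in place of chloro when cyclopropyl is on the sulfonyl sulfur, a much larger step than the one seen when methyl is there: the same change on two cores in this assay, a number 13 percentage points lower (beyond the scatter) from compound 2 to compound 3 and a number 41 percentage points lower (beyond the scatter) from compound 4 to compound 1, 28 percentage points apart, beyond the scatter of two such steps. Compound 4 at 78% and compound 3 at 85% each carry one of the two changes and lie within the scatter of each other, while compound 1, which carries both, stands at 37%, so the two changes do not simply add up.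

These four compounds cannot show whether this interplay extends to other groups on the sulfonyl sulfur, such as ethyl or dimethylamino, or to fluoro in place of chloro. The numbers also do not tell where in any of these compounds the loss takes place.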